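Fluorine on the biaryl of a fatty acid receptor agonist

A few compounds are considered here, and "the series" means these few. Any claim that something is new, unique, unknown or untested is made for them only; others in the source may bear on it.

Measured so far:
compound 2, `Cc1ccccc1-c1cccc(COc2ccc([C@H](CC(=O)O)c3nccn3C)cc2)c1` — 89000 nM
compound 3, `Cc1cc(Cl)ccc1-c1cccc(COc2ccc([C@H](CC(=O)O)c3nccn3C)cc2)c1C` — 23000 nM
compound 1, `COc1ccc(-c2cccc(COc3ccc([C@H](CC(=O)O)c4nccn4C)cc3)c2)cc1` — "not determined" (no result reported)

The three compounds share one core and differ in the aryl group attached to the benzyl ether. In an assay on CHO cells for agonist activity at Free fatty acid receptor 1 (Homo sapiens), read by luminescence, with a stated time of 20 s, in the presence of a further agent that is not named here (a lower number here means that less compound is needed, a higher number that more compound is needed for the effect), compound 2 gives 89000 nM, the highest number among the two values recorded; compound 3 in this assay gives 23000 nM, a lower number, and that gap lies beyond the usual scatter. For compound 1 the entry in this assay reads "not determined" (no result reported), so no number was obtained.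

Compound 4, `Cc1ccc(F)cc1-c1cccc(COc2ccc([C@H](CC(=O)O)c3nccn3C)cc2)c1`, is unmeasured. It differs from compound 2 in one place: fluoro in place of hydrogen on an aromatic carbon. Among the measured compounds shown here, no step between two measured compounds mirrors this single change, so the direction must be read only from what compound 2 and compound 3 show, and there the more substituted aryl of compound 3 gives the lower number. On that basis the author expects compound 4 to move toward a somewhat lower number than compound 2, by the modest step of a 1.5-fold lower number from compound 2 to compound 4 (0.17 log units; within the scatter), but a step that may still sit within the scatter. The estimate for compound 4 in this assay is 60000 nM, with a range from 25000 nM to 140000 nM.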

Compound 4, half-maximal effective concentration: 42000 nM
The estimate for compound 4 lay 1.4-fold (0.15 log units) above the measured number; the range from low to high includes it.
By their numbers in this assay, from the lowest: compounds 3 and 4 (each within the scatter of the next); then compound 2.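

The series now has its first step of a single change: in this assay, going from 2-methylphenyl to 5-fluoro-2-methylphenyl gives a 2.1-fold lower number from compound 2 to compound 4 (0.33 log units; beyond the scatter) and so ties a change in the number to one added atom. It shows that a fluoro on this aromatic carbon, para to a methyl group and meta to a large group, is tolerated without any rise in the number, and that one heavy atom at this place is enough to produce a step of modest size. The earlier compounds could not show this, since they differ from each other in more than one place; nothing measured here bears on why the number falls at this position.

The compounds shown leave open whether this step belongs to fluoro itself or would also appear with a trifluoromethyl group or a nitrile on the same aromatic carbon. They also leave open whether a fluoro on another carbon of this ring, or on a ring without the methyl group, would give a step of the same direction and size.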